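The source may hold more compounds than are shown below. What is called first, only, known or untested is meant among the compounds shown, and "the series" means these compounds.

Measured so far in an assay on isolated protein for inhibition of aldehyde dehydrogenase 1A1 (Homo sapiens), read by spectrophotometry, tested at 10 uM; on this read-out higher numbers stand for more inhibition at the one concentration tested (going by the name of the read-out) and lower numbers for less inhibition:

compound 1 `CC(C)=CCn1c(CN2CCN(C(=O)C3CC3)CC2)nc2ccccc21`: 74.3%
compound 2 `Cc1ccc(C(=O)N2CCN(Cc3nc4ccccc4n3Cc3cccc(C)c3)CC2)cc1`: 64.9%

Compound 1 gives the higher of the two numbers, but compound 2 lies within the scatter of it, so no order between the two is read. Among the compounds with values here, no step between measured compounds is known for any single change.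

Compound 3 `CC(C)Cn1c(CN2CCN(C(=O)C3CC3)CC2)nc2ccccc21` is not yet measured in this assay. It differs from compound 1 by isopropyl in place of 2-methylprop-1-en-1-yl on a saturated chain carbon bound to an aromatic nitrogen. Within the data shown here, no measured pair shows this change, so the expectation rests on compound 1 alone, with a small downward step or none beyond the scatter expected. For compound 3 the expected inhibition is 66%, in the range 48% to 80%. The estimated step is a number 8.3 percentage points lower from compound 1 to compound 3 (within the scatter).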

Compound 3, a percentage reported as inhibition, at one concentration (the size of the read-out at that concentration, not a potency): 13.1%
Estimate against measurement, compound 3: 52.9 percentage points above, and the stated range ends above it.
By their numbers in this assay, from the lowest: compound 3; then compounds 2 and 1 (each within the scatter of the next).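

In this assay, within the data shown here, the group on this saturated chain carbon bound to an aromatic nitrogen strongly affects the read-out: isopropyl in place of 2-methylprop-1-en-1-yl gives a number 61.2 percentage points lower from compound 1 to compound 3 (beyond the scatter), a step no earlier pair could show. Read one bond further out as 3-methylbut-2-en-1-yl to isobutyl, the change removes the double bond and alters the carbon count together, so this one step cannot separate the two. Nothing available explains the drop.

From the compounds shown here alone, whether a longer saturated chain such as pentyl would recover the inhibition remains open. So does the effect of a cyclopropylmethyl group here.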